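The source may hold more compounds than are shown below. What is called first, only, known or untested is meant among the compounds shown, and "the series" means these compounds.

Compound 3 `COc1cccc(/C=C/C(=O)OC/C=C/c2cc(OC)c(OC)cc2OC)c1` stands at 100% in a functional assay on the whole organism (strain Kunming) with Mus musculus as the target, with a stated time of 0.5 h, at a dose of 100 mg/kg by the intraperitoneal route; a lower number here means a stronger effect, a higher number a weaker effect of the compound at the dose given. That puts it level with compound 1 `COc1cc(OC)c(OC)cc1/C=C/COC(=O)/C=C/c1ccc(OC)c(OC)c1`, which gives 100%, and with compound 2 `COc1cc(OC)c(OC)cc1/C=C/COC(=O)/C=C/c1cccc(Br)c1`, which gives 100%; the steps of no change at the digits printed from compound 1 to compound 3 (within the scatter) and no change at the digits printed from compound 2 to compound 3 (within the scatter) both stay within the scatter. Compound 4 `COc1cc(OC)c(OC)cc1/C=C/COC(=O)/C=C/c1ccc(Cl)cc1` differs from compound 3 by 4-chlorophenyl in place of 3-methoxyphenyl on a double-bonded chain carbon bound to a double-bonded chain carbon. For the measured compounds named here, the closest precedent is the swap of one aryl group for another in no change at the digits printed from compound 1 to compound 2 (within the scatter), where a 3-bromophenyl took the place of a 3,4-dimethoxyphenyl on a double-bonded chain carbon bound to a double-bonded chain carbon and nothing moved beyond the scatter; the methoxy-for-bromo exchange in no change at the digits printed from compound 2 to compound 3 (within the scatter) was equally flat. Every aryl variation at this position among compounds 1, 2 and 3 has left the activity where it was, so no step beyond the scatter is expected in either direction when a 4-chlorophenyl enters. The expected step of no change at the digits printed from compound 3 to compound 4 (within the scatter) is therefore flat. Compound 4 is estimated at 100%, within a range from 88% to 100%.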

Compound 4, a percentage reported as activity, at one dose (the size of the read-out at that dose, not a potency): 100%
Compound 4: middle estimate and measured number agree at the digits printed; the range from low to high includes it.
By their numbers in this assay, from the lowest: compounds 1, 2, 3 and 4 (each within the scatter of the next).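

In this assay, the 4-chlorophenyl group behaves like the three aryl groups before it: no change at the digits printed from compound 3 to compound 4 (within the scatter), no change at the digits printed from compound 2 to compound 4 (within the scatter) and no change at the digits printed from compound 1 to compound 4 (within the scatter). This extends the flat picture at this place on the double-bonded chain carbon to a chlorine-bearing ring, with the substituent named at the 4 position alone, and so neither the 3-methoxyphenyl nor the 3-bromophenyl nor the 3,4-dimethoxyphenyl group is set apart from it. No measurement is available that could account for this lack of response.

As far as these compounds go, what remains open is whether any group at this place can move the read-out, for example a phenyl ring carrying an amine or a carboxylic acid, or a longer alkyl chain in place of the ring. The compounds shown also leave open whether changes to the shared core or to the ester linkage would shift the number.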